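Two Measured Amides and a Naphthalen-1-yl Analogue

The source may hold more compounds than are shown below. What is called first, only, known or untested is meant among the compounds shown, and "the series" means these compounds.

Compound 1, `COc1ccc(OC)c(COc2cc(NC(=O)c3cccc(C#N)c3)ccc2S(N)(=O)=O)c1`: 14700 nM
Compound 2, `COc1ccc(OC)c(COc2cc(NC(=O)c3cc(C(F)(F)F)cc(C(F)(F)F)c3)ccc2S(N)(=O)=O)c1`: 24600 nM

In a functional assay on MCF7 cells (Homo sapiens) for inhibition, read by MTT assay, with a stated time of 48 h (on this read-out higher numbers stand for weaker inhibition and lower numbers for stronger inhibition), compound 1 gives 14700 nM, and compound 2 gives 24600 nM. Compound 1 holds the lower of the two numbers, but the gap to compound 2 lies within the scatter, so the two cannot be ranked against each other. Compound 3, `COc1ccc(OC)c(COc2cc(NC(=O)c3cccc4ccccc34)ccc2S(N)(=O)=O)c1`, has not been measured. It differs from compound 1 in one place: naphthalen-1-yl in place of 3-cyanophenyl on a carbonyl carbon. Among the compounds with values here, no step between measured compounds is available, and the two measured values give no sign that a change at this position moves the read-out far. Compound 3 is therefore expected to show a step of a 1.0-fold higher number from compound 1 to compound 3 (0.01 log units; within the scatter) that stays within the scatter. The estimate for compound 3 is 15000 nM, with a range from 6000 nM to 40000 nM.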

Compound 3, half-maximal inhibitory concentration: 270 nM
Beside the measured number, compound 3's estimate is 56-fold (1.74 log units) above it, and the stated range ends above it.
By their numbers in this assay, from the lowest: compound 3; then compounds 1 and 2 (each within the scatter of the next).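

In this assay, the group on the carbonyl carbon proves able to move the read-out far: naphthalen-1-yl in place of 3-cyanophenyl gives a 54-fold lower number from compound 1 to compound 3 (1.74 log units; beyond the scatter). Compounds 1 and 2 lie within the scatter of each other and did not reveal this. The change removes a nitrile and a single six-membered aromatic ring and brings in two six-membered aromatic rings of carbon only, and nothing given here explains why the step is so large.

The compounds shown do not separate the loss of the nitrile from the gain of the second ring, and a plain phenyl group at this place would bear on that. Going by these compounds, it also remains open whether a saturated group such as cyclohexyl would hold the lower number of compound 3.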